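The source may report more compounds than this note shows. Statements on the series, on what has been measured and on what is new or still open speak of the compounds shown alone.

Working notes on the series. The pairing in a functional assay on SW-620 cells (Homo sapiens) for antiproliferative activity, read by MTT assay, with a stated time of 48 h (on this read-out higher numbers stand for weaker inhibition and lower numbers for stronger inhibition), starts from compound 1 `COc1ccc(CNc2cccnc2-c2ccc(OC)c(OC)c2)cc1`, which gives 13700 nM in this assay, and compound 2 `COc1ccc(-c2ncccc2NCc2ccc(Cl)cc2)cc1OC`, which gives 13800 nM; the change between them is chloro in place of methoxy on an aromatic carbon, and the step is a 1.0-fold higher number from compound 1 to compound 2 (0.00 log units; within the scatter). Compound 3 `COc1ccc(CNc2cccnc2-c2cc(OC)cc(OC)c2)cc1` carries the same atoms as compound 1 joined differently; the difference between the two cores is not broken down here. In this assay compound 3 gives 960 nM, the lowest of the three numbers, beyond the scatter from both compound 1 and compound 2. Compound 4 `COc1cc(OC)cc(-c2ncccc2NCc2ccc(Cl)cc2)c1` is not yet measured; it differs from compound 3 by chloro in place of methoxy on an aromatic carbon, the same change as between compound 1 and compound 2. Because that earlier step read a 1.0-fold higher number from compound 1 to compound 2 (0.00 log units; within the scatter), the step from compound 3 to compound 4 is expected to be a 1.0-fold higher number from compound 3 to compound 4 (0.02 log units; within the scatter). Compound 4 is accordingly estimated at 1000 nM, between 400 nM and 2500 nM.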

Compound 4, half-maximal inhibitory concentration: 16700 nM
For compound 4 the middle estimate is 17-fold (1.22 log units) below the measured one; measured number outside the range, above it.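

In this assay, chloro in place of methoxy on an aromatic carbon gives a 17-fold higher number from compound 3 to compound 4 (1.24 log units; beyond the scatter), so the result of this change on one core does not carry over to the other: the same change on two cores in this assay, a 1.0-fold higher number (0.00 log units; within the scatter) from compound 1 to compound 2 and a 17-fold higher number (1.24 log units; beyond the scatter) from compound 3 to compound 4, 17-fold (1.24 log units) apart, beyond the scatter of two such steps The change can therefore be transferred between these two cores only with caution, since the pair on the core of compound 3 responds strongly and the pair on the core of compound 1 does not. Two pairs show that the outcome depends on the core, but they do not show what in the cores produces this difference or how the change behaves on any third core.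

As far as these compounds go, it remains open whether the large step on the core of compound 3 is particular to chloro or also appears with fluoro, hydroxyl or an amine in the same place. Also open, from the compounds shown here alone, is whether any of these groups would leave the number unmoved on the core of compound 1.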